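The source may report more compounds than this note shows. Statements on the series, on what has been measured and on what is new or still open speak of the compounds shown alone.

The series shares one core, carried by compound 1 `C=CC(=O)Nc1cc2c(N3CCc4ccccc43)ncnc2cc1OC`, compound 2 `C=CC(=O)Nc1cc2c(N3CCc4ccccc43)ncnc2cc1O[C@@H]1CCOC1` and compound 3 `COc1cc2ncnc(N3CCc4ccccc43)c2cc1NC(=O)/C=C/CN(C)C`. In a functional assay on PC-3 cells (Homo sapiens) for antiproliferative activity, read by MTT assay, with a stated time of 72 h (a lower number here means a stronger inhibitor, a higher number a weaker inhibitor), compound 1 gives 5940 nM. Compound 2 gives 2710 nM in this assay, and compound 3 gives 2190 nM. Compound 2 thus holds the second highest number of the three: its gap to compound 3 lies within the scatter, while a 2.2-fold lower number from compound 1 to compound 2 (0.34 log units; beyond the scatter) sets it apart from compound 1.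

The step now followed leads from compound 2 to compound 4 `CN1CCN(C/C=C/C(=O)Nc2cc3c(N4CCc5ccccc54)ncnc3cc2O[C@@H]2CCOC2)CC1`, an unmeasured compound. The change is 3-(4-methylpiperazin-1-yl)prop-1-en-1-yl in place of vinyl on a carbonyl carbon.

Among the compounds with values here, one measured step bears directly on this: a 2.7-fold lower number from compound 1 to compound 3 (0.43 log units; beyond the scatter), where the vinyl on the carbonyl carbon likewise gave way to a chain carrying a basic amine, there 3-(dimethylamino)prop-1-en-1-yl. That step was modest but beyond the scatter. The step of a 2.2-fold lower number from compound 1 to compound 2 (0.34 log units; beyond the scatter) tells of a different change and so only fixes the starting point. Compound 4 is therefore expected to give a lower number than compound 2 in this assay, by about the size seen for compound 3, and its estimated value is 1100 nM, with a range from 450 nM to 2800 nM. The step this implies, a 2.5-fold lower number from compound 2 to compound 4 (0.39 log units; beyond the scatter), is expected to be modest.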

Compound 4, half-maximal inhibitory concentration: 4210 nM
Compound 4: the middle estimate sits 3.8-fold (0.58 log units) below what was measured, outside the stated range (above it).
By their numbers in this assay, from the lowest: compounds 3, 2, 4 and 1 (each within the scatter of the next, the first and the last beyond it).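

In this assay, putting 3-(4-methylpiperazin-1-yl)prop-1-en-1-yl in place of vinyl on the carbonyl carbon of the oxolan-3-yl compound gives a step that stays inside the usual scatter (a 1.6-fold higher number from compound 2 to compound 4 (0.19 log units; within the scatter)). The only earlier replacement at this place, with 3-(dimethylamino)prop-1-en-1-yl on the methyl compound, was printed as beyond the scatter (a 2.7-fold lower number from compound 1 to compound 3 (0.43 log units; beyond the scatter)), so a chain carrying an amine at this position does not give a step beyond the scatter in every case shown. Compound 3 and compound 4 differ in both the amine and the group on the oxygen, and no information is available that would account for the contrast between these two steps.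

The compounds shown leave open whether the two steps part with the amine at the end of the chain or with the group on the oxygen, a question that 3-(dimethylamino)prop-1-en-1-yl on the oxolan-3-yl compound would address. They also leave open how a morpholine ring in place of the 4-methylpiperazine ring would read at this position.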